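Fluorine in Place of a Nitrile on the Benzyloxy Arm

The source may hold more compounds than are shown below. What is called first, only, known or untested is meant among the compounds shown, and "the series" means these compounds.

Compound 1 `Cc1cc(C)cc(COc2ccc(-c3cc(CN4CCN(Cc5ccc(C(F)(F)F)cc5)CC4)no3)cc2)c1` gives 600 nM in a functional assay on Huh-7 cells (Homo sapiens) for antiproliferative activity, read by sulforhodamine B assay, with a stated time of 72 h; on this read-out lower numbers stand for stronger inhibition and higher numbers for weaker inhibition.
Compound 2 `FC(F)(F)c1ccc(CN2CCN(Cc3cc(-c4ccc(OCc5cccc(Cl)c5)cc4)on3)CC2)cc1` gives 200 nM.
Compound 3 `N#Cc1ccc(COc2ccc(-c3cc(CN4CCN(Cc5ccc(C(F)(F)F)cc5)CC4)no3)cc2)cc1` gives 1000 nM.

Compound 3 has the highest number of the three. The step of a 1.7-fold higher number from compound 1 to compound 3 (0.22 log units; within the scatter) lies within the scatter, so those two cannot be ordered; the step of a 5.0-fold higher number from compound 2 to compound 3 (0.70 log units; beyond the scatter) lies beyond the scatter, so compound 2 is the only one of the three that is clearly stronger than compound 3.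

Compound 4 `Fc1ccc(COc2ccc(-c3cc(CN4CCN(Cc5ccc(C(F)(F)F)cc5)CC4)no3)cc2)cc1` differs from compound 3 in one place: fluoro in place of cyano on an aromatic carbon. Going by the values given here, no measured step changes this same cyano group, so the closest guide is that all three measured steps alter the aryl group on the same benzyloxy arm, and each moved the number modestly at most: a 3.0-fold lower number from compound 1 to compound 2 (0.48 log units; beyond the scatter), a 1.7-fold higher number from compound 1 to compound 3 (0.22 log units; within the scatter), a 5.0-fold higher number from compound 2 to compound 3 (0.70 log units; beyond the scatter). Among them, the chloro-bearing compound 2 gave the lowest number, while the cyano-bearing compound 3 gave the highest. Fluoro in place of cyano is therefore expected to move the number down modestly, if at all: a 2.0-fold lower number from compound 3 to compound 4 (0.30 log units; within the scatter). Compound 4 is expected to give about 500 nM, between 200 nM and 1200 nM.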

Compound 4, half-maximal inhibitory concentration: 2000 nM
The estimate for compound 4 lay 4.0-fold (0.60 log units) below the measured number; measured number outside the range, above it.
By their numbers in this assay, from the lowest: compound 2; then compounds 1, 3 and 4 (each within the scatter of the next, the first and the last beyond it).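

The swap of cyano for fluoro on this aromatic carbon gives a 2.0-fold higher number from compound 3 to compound 4 (0.30 log units; within the scatter), so compound 3 and compound 4 cannot be ordered, and on this evidence the two groups are not told apart at this position in this assay. The swap does show something about how compound 4 sits against the other arms: a 3.3-fold higher number from compound 1 to compound 4 (0.52 log units; beyond the scatter) is beyond the scatter, whereas the step to compound 3 from the same starting point was not. With a 10-fold higher number from compound 2 to compound 4 (1.00 log units; beyond the scatter) as the largest step in the set, the 3-chlorophenyl arm of compound 2 stands clearly apart from the 4-cyanophenyl and 4-fluorophenyl arms, and replacing one of those two with the other does not close that gap.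

Still open, as far as these compounds go, is whether the lower number of compound 2 belongs to the chlorine itself or to where it sits on the ring, a question that a 4-chlorophenyl or 3-fluorophenyl arm could address, and whether an amine or a carboxylic acid on that ring would behave differently. Nothing measured here explains why these numbers fall as they do.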